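The source may hold more compounds than are shown below. What is called first, only, known or untested is meant among the compounds shown, and "the series" means these compounds.

In an assay on CHO-K1 cells for antagonist activity at adenosine receptor A1 (Homo sapiens), read by a beta-galactosidase reporter, with stated times of 15 min and 6 h (a lower number here means a stronger inhibitor, a higher number a weaker inhibitor), compound 2 `N#Cc1cccc(-c2nc(N)c3cc(CN4CCC(F)CC4)sc3n2)c1` gives 2950 nM. Among the two numbers measured so far it stands alongside compound 1 `Nc1nc(-c2cocn2)nc2sc(CN3CC=CCC3)cc12`, which in this assay gives 2960 nM, a gap that lies within the scatter. Compound 3 `N#Cc1cccc(-c2nc(N)c3cc(CN4CC=CCC4)sc3n2)c1` differs from compound 2 by a group of 6 heavy atoms (5 carbon, 1 nitrogen; one six-membered non-aromatic ring with 1 hetero atom) in place of a group of 7 heavy atoms (5 carbon, 1 nitrogen, 1 fluorine; one six-membered non-aromatic ring with 1 hetero atom), on a saturated chain carbon bound to an aromatic carbon. Going by the values given here, no pair of measured compounds differs in this one place alone, so there is no measured step to lean on. Compound 1 already carries the entering group and gives 2960 nM in this assay. On that basis the step from compound 2 to compound 3 is expected to be a 1.0-fold higher number from compound 2 to compound 3 (0.01 log units; within the scatter), nothing beyond the scatter. Compound 3 is therefore estimated at 3000 nM, with a range from 1000 nM to 9000 nM.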

Compound 3, inhibition constant: 210 nM
For compound 3 the middle estimate is 14-fold (1.15 log units) above the measured one; measured number outside the range, below it.
By their numbers in this assay, from the lowest: compound 3; then compounds 2 and 1 (each within the scatter of the next).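

In this assay the ring with one double bond in place of 4-fluoropiperidin-1-yl gives a 14-fold lower number from compound 2 to compound 3 (1.15 log units; beyond the scatter) and 3-cyanophenyl in place of 1,3-oxazol-4-yl gives a 14-fold lower number from compound 1 to compound 3 (1.15 log units; beyond the scatter) on the aromatic carbon. Both places therefore matter, which the matching values of compound 1 and compound 2 concealed: only compound 3 carries both entering groups. Nothing measured here explains either step. The compounds shown leave open whether the gain follows the presence of the double bond or the absence of fluorine; a plain piperidine ring would separate the two.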